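This account rests on a few compounds, and the source may have more. Where it says the series, first, only, none or still open, it means among the compounds named here.

Working notes on the series.

Within the data shown here, compound 3 `O=S(=O)(NCCCNCc1ccc(Br)cc1)c1cc(C(F)(F)F)cc(C(F)(F)F)c1` stands in a functional assay on MIA PaCa-2 cells (Homo sapiens) for inhibition, read by MTT assay, with a stated time of 72 h (a higher number here means a weaker inhibitor of growth, a lower number a stronger inhibitor of growth), at 2300 nM, level with compound 1 `CC(C)(C)c1ccc(CNCCCNS(=O)(=O)c2cc(C(F)(F)F)cc(C(F)(F)F)c2)cc1`, which gives 2300 nM; together these are the lowest of the three numbers so far. Compound 2 `O=S(=O)(NCCCNCc1ccccc1)c1cc(C(F)(F)F)cc(C(F)(F)F)c1` gives 11000 nM. The steps of a 4.8-fold lower number from compound 2 to compound 3 (0.68 log units; beyond the scatter) and a 4.8-fold higher number from compound 1 to compound 2 (0.68 log units; beyond the scatter) both show that a substituent on that aromatic carbon lowers the number, while no change at the digits printed from compound 1 to compound 3 (within the scatter) shows that bromo and tert-butyl are interchangeable there.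

Compound 4 `O=S(=O)(NCCCNCc1ccc(-c2ccccc2)cc1)c1cc(C(F)(F)F)cc(C(F)(F)F)c1` carries the change (phenyl in place of bromo on an aromatic carbon). The bearing steps are a 4.8-fold lower number from compound 2 to compound 3 (0.68 log units; beyond the scatter), which is modest, and no change at the digits printed from compound 1 to compound 3 (within the scatter), which is within the scatter; nothing measured distinguishes a phenyl from the other two groups at this place. Since both groups tried so far on that aromatic carbon gave the same number, the expectation for compound 4 is a step of a 1.3-fold lower number from compound 3 to compound 4 (0.11 log units; within the scatter), that is, no change beyond the scatter. Compound 4 is therefore estimated at 1800 nM, with a range from 700 nM to 5000 nM.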

Compound 4, concentration for 50% growth inhibition: 2400 nM
Compound 4: middle estimate off by 1.3-fold (0.12 log units), on the low side, within the range that was stated.
By their numbers in this assay, from the lowest: compounds 1, 3 and 4 (each within the scatter of the next); then compound 2.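

In this assay, the aromatic carbon para to a large group accepts phenyl as readily as bromo (a 1.0-fold higher number from compound 3 to compound 4 (0.02 log units; within the scatter)) or tert-butyl (a 1.0-fold higher number from compound 1 to compound 4 (0.02 log units; within the scatter)), although phenyl brings six heavy atoms and a six-membered aromatic ring where bromo has a single bromine atom. The step from hydrogen stays beyond the scatter with this ring in place (a 4.6-fold lower number from compound 2 to compound 4 (0.66 log units; beyond the scatter)), so all three substituents tried at this place give a lower number than hydrogen and cannot be told apart from each other. No measurement in hand bears on why these three groups read alike.

From the compounds shown here alone, whether this level holds with an amine, a carboxylic acid or a methoxy group on the same carbon remains open. Also open, going by these compounds, is how a longer chain in place of the propyl linker would read with any of these groups.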